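The compounds below may be only part of what the source reports. "The series", "measured", "known", "first", "only" and "open" are said of these compounds alone.

Working notes on the series. In a functional assay on the whole organism for inhibition, with Scenedesmus acutus as the target (a higher number here means a weaker inhibitor, a lower number a stronger inhibitor), compound 1 (`O=C(O)c1cc(N2C(=O)C3=C(CCCC3)C2=O)c(F)cc1Cl`) gives 1000 nM and compound 3 (`CCOC(=O)c1cc(N2C(=O)C3=C(CCCC3)C2=O)c(F)cc1Cl`) gives 57.5 nM. Compound 2 (`O=C(O)c1cc(N2C(=O)C3=C(CCCC3)C2=O)ccc1Cl`) is recorded only as a limit, > 100000 nM. Compound 4 (`CC(C)OC(=O)c1cc(N2C(=O)C3=C(CCCC3)C2=O)ccc1Cl`) has isopropyl in place of hydrogen on an oxygen next to a carbonyl group. The closest measured change, ethyl in place of hydrogen on such an oxygen, gave a 17-fold lower number from compound 1 to compound 3 (1.24 log units; beyond the scatter). Hydrogen in place of fluoro gave an at least 100-fold higher number from compound 1 to compound 2 (2.00 log units; beyond the scatter), and compound 4 also lacks that fluoro. A large move to a lower number is therefore expected in this assay, although it starts from a limit. The estimated change is an at least 16-fold lower number from compound 2 to compound 4 (1.22 log units; beyond the scatter). For compound 4 the estimate is 6000 nM, with an expected range of 800 nM to 40000 nM.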

Compound 4, half-maximal inhibitory concentration: 1230 nM
Beside the measured number, compound 4's estimate is 4.9-fold (0.69 log units) above it, within the range that was stated.
By their numbers in this assay, from the lowest: compound 3; then compounds 1 and 4 (each within the scatter of the next). At a limit, above all of these: compound 2.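

The step of an at least 81-fold lower number from compound 2 to compound 4 (1.91 log units; beyond the scatter) in this assay shows that an ester at this oxygen also lowers the number with isopropyl and without the fluoro. The earlier step of a 17-fold lower number from compound 1 to compound 3 (1.24 log units; beyond the scatter) in this assay covered only ethyl with the fluoro present. Compound 2 stands at a limit, so the new step gives a bound and not an exact size: the limit of > 100000 nM in this assay, at which 1 of the 4 values shown sits.

Open, as far as these compounds go, is whether ethyl and isopropyl differ on one shared core, and what the fluoro contributes once this oxygen carries either group. Also open, from the compounds shown here alone, is how a longer chain such as butyl, or an amine in place of this oxygen, would read.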